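Methoxy for Fluoro on a Pyrrole-Fused Acetyl Core

A few compounds are considered here, and "the series" means these few. Any claim that something is new, unique, unknown or untested is made for them only; others in the source may bear on it.

Three compounds share one core and differ only on the aryl rings. Compound 1 `CC(=O)c1cc(-c2ccc(F)cc2)cc2cc(-c3ccccc3)[nH]c12` carries a fluoro group on one ring, compound 2 `COc1ccc(-c2cc(C(C)=O)c3[nH]c(-c4ccccc4)cc3c2)cc1` bears a methoxy group in its place, and compound 3 `COc1ccc(-c2cc3cc(-c4ccc(F)cc4)cc(C(C)=O)c3[nH]2)cc1` keeps the fluoro group but adds a methoxy group on the other ring. In a functional assay on HeLa cells (Homo sapiens) for cytotoxicity, read by MTT assay, with a stated time of 2 days, tested at 100 uM (a lower number here means a stronger effect, a higher number a weaker effect of the compound at the concentration tested), compound 1 gives 24.8%, compound 2 gives 21.1% and compound 3 gives 46.5%. The change methoxy in place of fluoro on an aromatic carbon gave a number 3.7 percentage points lower from compound 1 to compound 2 (within the scatter). The two cores differ by methoxy in place of hydrogen on an aromatic carbon, which gave a number 21.7 percentage points higher from compound 1 to compound 3 (beyond the scatter), so compound 3 stands highest of the three.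

Compound 4 `COc1ccc(-c2cc(C(C)=O)c3[nH]c(-c4ccc(OC)cc4)cc3c2)cc1` is not yet measured; it differs from compound 3 by methoxy in place of fluoro on an aromatic carbon, the same change as from compound 1 to compound 2. Because that earlier step was a number 3.7 percentage points lower from compound 1 to compound 2 (within the scatter), the step in this assay from compound 3 to compound 4 is expected to be small, about a number 3.5 percentage points lower from compound 3 to compound 4 (within the scatter). Compound 4 is therefore estimated at 43%, between 30% and 58%.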

Compound 4, a percentage reported as activity, at one concentration (the size of the read-out at that concentration, not a potency): 20.2%
Compound 4: the middle estimate sits 22.8 percentage points above what was measured, and the stated range ends above it.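

In this assay, the change from 4-fluorophenyl to 4-methoxyphenyl gave a number 26.3 percentage points lower from compound 3 to compound 4 (beyond the scatter), so its size did not carry over from one core to the other: the same change on two cores in this assay, a number 3.7 percentage points lower (within the scatter) from compound 1 to compound 2 and a number 26.3 percentage points lower (beyond the scatter) from compound 3 to compound 4, 22.6 percentage points apart, beyond the scatter of two such steps

Methoxy in place of hydrogen on an aromatic carbon likewise failed to transfer, giving a number 0.9 percentage points lower from compound 2 to compound 4 (within the scatter): the same change on two cores in this assay, a number 21.7 percentage points higher (beyond the scatter) from compound 1 to compound 3 and a number 0.9 percentage points lower (within the scatter) from compound 2 to compound 4, 22.6 percentage points apart, beyond the scatter of two such steps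

Among these four compounds, the outcome of each change therefore depends on what the other aryl ring carries, with compound 3 standing apart from the other three, but one pair of steps per change cannot show why this happens or whether it extends beyond this set.

The compounds shown leave open how the series responds to other groups on the aryl rings, such as an amine or a carboxylic acid, or to a longer chain in place of the acetyl group. They also leave open how these compounds behave at other concentrations, since each reading comes from a single tested concentration.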